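The source may hold more compounds than are shown below. What is called first, only, known or untested is meant among the compounds shown, and "the series" means these compounds.

Going by the values given here, compound 1 `O=C1/C(=N\NC(=S)Nc2ccc(Cl)cc2)c2cc(Cl)ccc2N1Cc1ccc(Cl)cc1` is one of two compounds measured in a functional assay on MOLT-4 cells (Homo sapiens), with a stated time of 72 h (a lower number here means a stronger inhibitor, a higher number a weaker inhibitor), where compound 1 gives 58000 nM. Among the compounds with values here, this is the highest of the two numbers, but its only neighbour, compound 2 `O=C1/C(=N\NC(=S)Nc2ccc(Cl)cc2)c2cc(Cl)ccc2N1Cc1ccc(F)cc1`, lies close: in this assay compound 2 gives 48000 nM, and the step of a 1.2-fold lower number from compound 1 to compound 2 (0.08 log units; within the scatter) stays within the scatter, so no order between them can be read off.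

Compound 3 `O=C1/C(=N\NC(=S)Nc2ccc(Cl)cc2)c2cc(Br)ccc2N1Cc1ccc(Cl)cc1` differs from compound 1 in one place: bromo in place of chloro on an aromatic carbon. Within the data shown here, the single measured step, from compound 1 to compound 2, is a halogen exchange at a different position and changed nothing beyond the scatter; no measured step covers a bromo-for-chloro exchange at the position in question. On that basis, a step of no more than the scatter is expected from compound 1 to compound 3, as a 1.2-fold lower number from compound 1 to compound 3 (0.06 log units; within the scatter). Compound 3 is therefore estimated at 50000 nM in this assay, with a range from 22000 nM to 110000 nM.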

Compound 3, half-maximal inhibitory concentration: 280000 nM
Estimate against measurement, compound 3: 5.6-fold (0.75 log units) below, and the stated range ends below it.
By their numbers in this assay, from the lowest: compounds 2 and 1 (each within the scatter of the next); then compound 3.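

In this assay, bromo in place of chloro on an aromatic carbon of the ring that is part of the fused system of two rings gives a 4.8-fold higher number from compound 1 to compound 3 (0.68 log units; beyond the scatter) and so makes a weaker inhibitor. The halogen exchange at the other position, a 1.2-fold lower number from compound 1 to compound 2 (0.08 log units; within the scatter) by contrast, stayed within the scatter, so this is the first sign among these compounds that the choice of halogen can matter, and it comes from a single exchange at this position. Nothing available bears on why this step is as large as it is.

The compounds shown leave open how this position responds to anything other than chloro and bromo, such as a hydrogen, a fluoro, a methoxy group or an amine. They also leave open whether bromo has the same effect when the fluoro replaces the chloro at the other position.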